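From Fluorine to Methyl on the Cyclopropyl Amide

The compounds below may be only part of what the source reports. "The series", "measured", "known", "first", "only" and "open" are said of these compounds alone.

Going by the values given here, compound 2 `O=C([C@H]1C[C@H]1F)N1CC2CC(C1)N2` holds the lowest number of the two compounds measured so far in an assay on SH-EP1 cells for agonist activity at Neuronal acetylcholine receptor; alpha4/beta2 (Homo sapiens), read by FLIPR and calcium flux; on this read-out lower numbers stand for an effect already at smaller amounts and higher numbers for an effect only at larger amounts of compound: compound 2 gives 210 nM. Among the compounds with values here, its only neighbour, compound 1 `O=C(C1CCC1)N1CC2CC(C1)N2`, gives 2900 nM in this assay, and the step of a 14-fold lower number from compound 1 to compound 2 (1.14 log units; beyond the scatter) is the single measured comparison available. Compound 3 `C[C@H]1C[C@H]1C(=O)N1CC2CC(C1)N2` differs from compound 2 in one place: 2-methylcyclopropyl in place of 2-fluorocyclopropyl on a carbonyl carbon. Within the data shown here, the measured step bears on this change only indirectly: it exchanged a cyclobutyl for a 2-fluorocyclopropyl and thus altered ring size and fluorine at once, and no measured pair separates the fluorine from the ring. A modest move, most likely towards a higher number, is expected. Compound 3 is estimated to give 500 nM, with a range from 150 nM to 2000 nM, which means an expected step of a 2.4-fold higher number from compound 2 to compound 3 (0.38 log units; beyond the scatter).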

Compound 3, half-maximal effective concentration: 2200 nM
Estimate against measurement, compound 3: 4.4-fold (0.64 log units) below; measured number above the stated range.
By their numbers in this assay, from the lowest: compound 2; then compounds 3 and 1 (each within the scatter of the next).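

Swapping only the 2-fluorocyclopropyl for 2-methylcyclopropyl on the carbonyl carbon, with the same ring size and the same number of heavy atoms, produces a large step in this assay (a 10-fold higher number from compound 2 to compound 3 (1.02 log units; beyond the scatter)). This separates what the first comparison could not: the three-membered ring alone does not bring the low number, since cyclobutyl and 2-methylcyclopropyl cannot be told apart here (a 1.3-fold lower number from compound 1 to compound 3 (0.12 log units; within the scatter)). Among these three compounds, the low number appears only with the fluorine on the cyclopropyl ring, in compound 2.

As far as these compounds go, whether a bare cyclopropyl, or a chlorine or hydroxyl in the fluorine's place, would sit nearer compound 2 or compound 3 remains open. Nothing available here explains why fluorine and methyl differ so strongly at this position.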